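The source may hold more compounds than are shown below. What is called first, only, known or untested is meant among the compounds shown, and "the series" means these compounds.

Compound 1 `CCn1nc(-c2cccnc2)c2ccccc2c1=O`: 87%
Compound 2 `CCCn1nc(-c2cccnc2)c2ccccc2c1=O`: 86%
Compound 3 `COCCn1nc(-c2cccnc2)c2ccccc2c1=O`: 55%

These three share one core and differ only in the saturated chain. In an assay on isolated protein (Oryctolagus cuniculus) with Thromboxane-A synthase (Homo sapiens) as the target, tested at 1 uM (a lower number here means less inhibition, a higher number more inhibition at the concentration tested (going by the name of the read-out)), compound 3 stands lowest of the three numbers, beyond the scatter from both of the others. Compound 4 `O=c1c2ccccc2c(-c2cccnc2)nn1CCSc1ncccn1` differs from compound 3 in one place: (pyrimidin-2-yl)sulfanyl in place of methoxy on a saturated chain carbon, two bonds along the chain from an aromatic nitrogen. Within the data shown here, no measured step brings in a (pyrimidin-2-yl)sulfanyl group on this chain, so the expectation rests on what the methoxy itself did: a number 32 percentage points lower from compound 1 to compound 3 (beyond the scatter) and a number 31 percentage points lower from compound 2 to compound 3 (beyond the scatter), whereas a number 1 percentage points lower from compound 1 to compound 2 (within the scatter). Compound 4 is therefore expected to recover much of that loss in this assay, an estimated a number 17 percentage points higher from compound 3 to compound 4 (beyond the scatter), though with wide uncertainty. Compound 4 is expected to give about 72%, within a range of 48% to 92%.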

Compound 4, a percentage reported as inhibition, at one concentration (the size of the read-out at that concentration, not a potency): 86%
Estimate against measurement, compound 4: 14 percentage points below; measured number inside the range.
By their numbers in this assay, from the lowest: compound 3; then compounds 2, 4 and 1 (each within the scatter of the next).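

In this assay, the drop seen with methoxy is not a penalty for any group beyond a plain chain at this place, since (pyrimidin-2-yl)sulfanyl gives a number 31 percentage points higher from compound 3 to compound 4 (beyond the scatter). This far larger, ring-bearing group matches the simple chains, with no change at the digits printed from compound 2 to compound 4 (within the scatter) and a number 1 percentage points lower from compound 1 to compound 4 (within the scatter), so the place on the saturated chain accepts it without visible loss. No supporting measurement bears on why methoxy alone stands apart. From the compounds shown here alone, it stays open whether the sulfur or the six-membered aromatic ring matters more, and how an amine, a carboxylic acid or a longer chain would behave here.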